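This account rests on a few compounds, and the source may have more. Where it says the series, first, only, none or still open, it means among the compounds named here.

Compound 3 (`N#Cc1ccc(CN([C@H](CCC(F)(F)F)C(N)=O)S(=O)(=O)c2ccc(Cl)cc2)cc1`) gives 19.7 10^-6 cm/s in an ADME assay on MDCKII-LE cells (Canis lupus familiaris) for permeability (a higher number here means that the compound crosses the layer faster, a lower number that the compound crosses the layer more slowly), and sits within the scatter of its two relatives, with compound 1 (`NC(=O)[C@@H](CCC(F)(F)F)N(CC12CC(c3ncon3)(C1)C2)S(=O)(=O)c1ccc(Cl)cc1`) at 19.3 10^-6 cm/s and compound 2 (`N#CC12CC(CN([C@H](CCC(F)(F)F)C(N)=O)S(=O)(=O)c3ccc(Cl)cc3)(C1)C2`) at 30.2 10^-6 cm/s on the same scale. Compound 4 (`N#CCCN([C@H](CCC(F)(F)F)C(N)=O)S(=O)(=O)c1ccc(Cl)cc1`) differs from compound 3 by one change (cyanomethyl in place of 4-cyanophenyl on a saturated chain carbon bound to a sulfonamide nitrogen), in words cyanomethyl in place of 4-cyanophenyl on a saturated chain carbon bound to a sulfonamide nitrogen. Two measured swaps at that place bear on it (a 1.0-fold higher number from compound 1 to compound 3 (0.01 log units; within the scatter); a 1.5-fold lower number from compound 2 to compound 3 (0.19 log units; within the scatter)), and a third swap, on a saturated ring carbon (a 1.6-fold higher number from compound 1 to compound 2 (0.19 log units; within the scatter)), adds to them. All three stayed within the scatter, but each of those compounds keeps a ring in this group and compound 4 has none, so the new step goes somewhat beyond the evidence. No shift beyond the scatter is expected in this assay (the estimated step is a 1.1-fold higher number from compound 3 to compound 4 (0.05 log units; within the scatter)). Compound 4 is estimated at 22 10^-6 cm/s with an expected range from 11 10^-6 cm/s to 40 10^-6 cm/s in this measurement.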

Compound 4, apparent permeability: 10.2 10^-6 cm/s
Compound 4: the middle estimate sits 2.2-fold (0.33 log units) above what was measured; measured number below the stated range.
By their numbers in this assay, from the lowest: compounds 4, 1, 3 and 2 (each within the scatter of the next, the first and the last beyond it).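

Going by these compounds alone, the ringless cyanomethyl group gives the first pair at this position to separate beyond the scatter in this assay, with a 3.0-fold lower number from compound 2 to compound 4 (0.47 log units; beyond the scatter) as the step from the group with two four-membered rings. The other two comparisons do not separate, with a 1.9-fold lower number from compound 3 to compound 4 (0.29 log units; within the scatter) for the direct swap from 4-cyanophenyl and a 1.9-fold lower number from compound 1 to compound 4 (0.28 log units; within the scatter) from the oxadiazole-bearing group, so only compound 2 stands clearly apart from compound 4. Nothing measured here gives a reason for that gap.

The compounds shown cannot tell whether the loss of any ring or the shorter chain itself sets the number in this assay. A longer chain ending in a nitrile, or a plain propyl chain with no nitrile, would help to separate these two readings.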